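Chloro for Fluoro on a Shared Diaryl Core

The compounds below may be only part of what the source reports. "The series", "measured", "known", "first", "only" and "open" are said of these compounds alone.

Compound 1, `Nc1ncc(-c2ccccc2)c(-c2ccccc2)n1`: 32%
Compound 2, `Cc1cccc(-c2cnc(N)nc2-c2ccccc2)c1`: > 80%, a limit of the assay
Compound 3, `Nc1ncc(-c2cccc(F)c2)c(-c2ccccc2)n1`: 63%

Three compounds share one core and differ only in a single group on an aromatic carbon. In an assay on CHO cells for displacement of a labelled ligand from adenosine receptor A1 (Homo sapiens), read by scintillation counting, with a stated time of 1 h, tested at 1 uM (a lower number here means less inhibition, a higher number more inhibition at the concentration tested (going by the name of the read-out)), compound 1 gives 32%. Compound 2 gives > 80%, which is a limit of the assay and not a number. Among the two plain numbers compound 3 stands highest, with 63%, and the step of a number 31 percentage points higher from compound 1 to compound 3 (beyond the scatter) sets it apart from its nearest neighbour.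

Compound 4, `Nc1ncc(-c2cccc(Cl)c2)c(-c2ccccc2)n1`, is not yet measured. The change is chloro in place of fluoro on an aromatic carbon. For the measured compounds named here, three measured steps bear on it: a number at least 48 percentage points higher from compound 1 to compound 2 (beyond the scatter), a number 31 percentage points higher from compound 1 to compound 3 (beyond the scatter) and a number at least 17 percentage points lower from compound 2 to compound 3 (beyond the scatter). A group on this carbon has so far raised the read-out, and methyl has done so more than fluoro, so chloro is expected to land between the two, above fluoro. For compound 4 the expected value is 74%, estimated between 55% and 90%. This expectation means a step of a number 11 percentage points higher from compound 3 to compound 4 (beyond the scatter).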

Compound 4, a percentage reported as inhibition, at one concentration (the size of the read-out at that concentration, not a potency): > 80%
Compound 4: only a limit was reported; the forecaster's own chance of this, stated with the estimate: 30%; middle value at least 6 percentage points from the limit.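

In this assay, exchanging one halogen for another on this aromatic carbon is not a neutral change: chloro in place of fluoro gives a number at least 17 percentage points higher from compound 3 to compound 4 (beyond the scatter), and chloro in place of hydrogen gives a number at least 48 percentage points higher from compound 1 to compound 4 (beyond the scatter). Compound 4 gives > 80%, which is a limit of the assay and not a number. The step from compound 2 to compound 4 cannot be read, so chloro and methyl cannot be put in order, because both compounds sit at the same limit: the limit of > 80% in this assay, at which 2 of the 4 values shown sit.

As far as these compounds go, whether chloro and methyl differ at all remains open, since only a read-out free of this limit could separate them. Also open, from the compounds shown here alone, is whether bromo, methoxy or an amine on the same carbon would give a read-out like that of chloro or one closer to that of fluoro.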